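This account rests on a few compounds, and the source may have more. Where it says the series, first, only, none or still open, it means among the compounds named here.

Working notes on the diaryl ether urea series.

Compound 2 `Cc1ccc(NC(=O)Nc2ccc(Oc3ccc(-c4nccs4)cc3)cc2)cc1` carries a 4-methylphenyl on one urea nitrogen. Going by the values given here, in a functional assay on A549 cells (Homo sapiens) for inhibition, read by MTT assay and WST assay, with a stated time of 72 h, tested at 10 uM (on this read-out higher numbers stand for more inhibition of growth at the one concentration tested and lower numbers for less inhibition of growth), compound 2 gives 15.6%, the lowest of the three numbers measured so far. Compound 1 `O=C(Nc1ccc(Oc2ccc(-c3nccs3)cc2)cc1)Nc1ccc(Cl)c([N+](=O)[O-])c1` gives 77.1% in this assay, and compound 3 `O=C(Nc1ccc(Oc2ccc(-c3nccs3)cc2)cc1)Nc1cc(Br)cc(C(F)(F)F)c1` gives 81.7%. The two steps that lead away from compound 2 are both large and beyond the scatter: a number 61.5 percentage points lower from compound 1 to compound 2 (beyond the scatter) and a number 66.1 percentage points higher from compound 2 to compound 3 (beyond the scatter). The step of a number 4.6 percentage points higher from compound 1 to compound 3 (within the scatter) stays within the scatter. All three measured steps vary only the aryl group on the urea nitrogen and leave the rest of the shared core untouched.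

Compound 4 `Cc1ccc(NC(=O)Nc2ccc(Oc3ccc(-c4ncc[nH]4)cc3)cc2)cc1` differs from compound 2 at the other end of the molecule: 1H-imidazol-2-yl in place of 1,3-thiazol-2-yl on an aromatic carbon. Among the compounds with values here, no measured step in this assay changes this part of the core, so none of the three steps bears directly on the move from compound 2 to compound 4. With the 4-methylphenyl urea kept as in compound 2, the value of compound 2 is the only anchor, and a step of either direction beyond the scatter has no support in the measured data. The estimated step is therefore a number 2.4 percentage points higher from compound 2 to compound 4 (within the scatter), expected to fall within the scatter. Compound 4 is estimated at 18% in this assay, with a range from 2% to 40%.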

Compound 4, percent growth inhibition at one concentration: 24.6%
Estimate against measurement, compound 4: 6.6 percentage points below, within the range that was stated.
By their numbers in this assay, from the lowest: compounds 2 and 4 (each within the scatter of the next); then compounds 1 and 3 (each within the scatter of the next).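

Going by these compounds alone, the first change at this end of the molecule, made with the 4-methylphenyl urea kept, gives a number 9 percentage points higher from compound 2 to compound 4 (within the scatter) in this assay, so 1H-imidazol-2-yl and 1,3-thiazol-2-yl on this aromatic carbon, para to a large group, cannot be told apart on this read-out. The exchange brings in a hydrogen-bond donor and leaves one hydrogen-bond acceptor in place of two, yet this change in counts comes with a step no larger than the scatter, whereas the change of aryl group on the urea nitrogen gives a number 66.1 percentage points higher from compound 2 to compound 3 (beyond the scatter). Nothing on hand accounts for the result at this position, and the reading stays an observation on this one pair.

What the compounds shown leave open is whether the same exchange would also stay within the scatter with a 3-bromo-5-(trifluoromethyl)phenyl or 4-chloro-3-nitrophenyl group on the urea nitrogen, where the numbers are much higher. They also leave open how a group of a different kind in this place, such as a carboxylic acid or a dimethylamino group, would read in this assay.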